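The source may hold more compounds than are shown below. What is called first, only, known or untested is meant among the compounds shown, and "the series" means these compounds.

Working notes on the series, read in a physicochemical assay for lipophilicity; a lower number here means a more polar compound, a higher number a more lipophilic compound. Compound 1 `CN(C)c1ccc(/C=C/C(=O)/C=C/c2ccc(I)cc2)cc1` gives 3.66. Compound 2 `Nc1ccc(/C=C/C(=O)/C=C/c2ccc(I)cc2)cc1` gives 3.26, and compound 3 `CNc1ccc(/C=C/C(=O)/C=C/c2ccc(I)cc2)cc1` gives 3.55. Compound 1 therefore stands within the scatter of compound 3 and beyond the scatter of compound 2. Among the measured compounds shown here, the one step beyond the scatter is a number 0.40 log units lower from compound 1 to compound 2 (beyond the scatter). The other two, a number 0.11 log units lower from compound 1 to compound 3 (within the scatter) and a number 0.29 log units higher from compound 2 to compound 3 (within the scatter), stay within it.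

Compound 4 `CN(C)c1ccc(/C=C/C(=O)/C=C/c2ccc(OCCOCCOCCF)cc2)cc1` keeps the dimethylamino group of compound 1 and differs from it as follows: 2-(2-(2-fluoroethoxy)ethoxy)ethoxy in place of iodo on an aromatic carbon. In short, 2-(2-(2-fluoroethoxy)ethoxy)ethoxy stands in place of iodo on an aromatic carbon, para to a large group. All three measured steps concern the nitrogen on an aromatic ring, and none exchanges the iodo group, so they serve only as a gauge of size. The direction rests on the structural change alone, with hydrogen-bond acceptors entering and none leaving. A lower number is expected, in a step somewhat larger than a number 0.40 log units lower from compound 1 to compound 2 (beyond the scatter) seen so far. The expected step is a number 0.66 log units lower from compound 1 to compound 4 (beyond the scatter), and it remains uncertain without a measured precedent at this position. Compound 4 is estimated at 3, with an expected range from 2.4 to 3.5.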

Compound 4, distribution coefficient: 2.97
Compound 4: middle estimate off by 0.03 log units, on the high side, and the stated range covers the measured number.
By their numbers in this assay, from the lowest: compounds 4, 2, 3 and 1 (each within the scatter of the next, the first and the last beyond it).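

In this assay, among the compounds shown here, a number 0.69 log units lower from compound 1 to compound 4 (beyond the scatter) is the only measured exchange at the aromatic carbon that carries iodo in compound 1, and it shows that this place, para to a large group, can move the read-out beyond the scatter while the dimethylamino group stays fixed. The step is larger in printed size than the change on the nitrogen, a number 0.40 log units lower from compound 1 to compound 2 (beyond the scatter), and here a group of 10 heavy atoms with 3 hydrogen-bond acceptors replaces a single iodine, so in this one pair the larger group goes with the lower number. No measurement at hand ties this step to a property of the iodo group or of the entering chain.

Still open, on these data alone, is which part of 2-(2-(2-fluoroethoxy)ethoxy)ethoxy carries the step, a question that a plain methoxy, a shorter 2-fluoroethoxy or a chain ending in hydroxyl instead of fluorine could separate at the same aromatic carbon. Also open, as far as these compounds go, is whether the same exchange gives a step of similar size with amino or methylamino on the nitrogen in place of dimethylamino.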